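Working notes on compound 4 and its amide change

The compounds below may be only part of what the source reports. "The series", "measured", "known", "first", "only" and "open" are said of these compounds alone.

compound 1 `C=CC1=C(C(=O)Nc2ccc(C)cc2)C(c2ccc(F)cc2)OC1`: 59200 nM
compound 2 `C=CC1=C(C(=O)Nc2ccc(OCC)cc2)C(c2ccc(F)cc2)OC1`: 61600 nM
compound 3 `C=CC1=C(C(=O)Nc2ccc(C)cc2)C(c2ccc(OC)cc2)OC1`: a limit, > 100000 nM

In a functional assay on QGY7701 cells (Homo sapiens) for cytotoxicity, read by MTT assay, with a stated time of 24 h (on this read-out higher numbers stand for weaker inhibition and lower numbers for stronger inhibition), compound 1 holds the lowest of the two numbers, and a 1.0-fold higher number from compound 1 to compound 2 (0.02 log units; within the scatter) keeps compound 2 level with it. For compound 3 the read-out is a limit (the limit of > 100000 nM in this assay, at which 1 of the 3 values shown sits), so an at least 1.6-fold higher number from compound 1 to compound 3 (0.22 log units; that floor lies within the scatter) is only a floor.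

Compound 4 `C=CC1=C(C(=O)NC2CCCCC2)C(c2ccc(F)cc2)OC1` differs from compound 1 by cyclohexyl in place of 4-methylphenyl on an amide-type nitrogen. Neither measured step touches the amide nitrogen: the ethoxy-for-methyl step stayed within the scatter, and the fluoro step gave only a floor. Within the data shown here, no precedent therefore fixes the size of this step; a number near compound 1, or a modest weakening, is the plainest expectation. Compound 4 is estimated at 72000 nM, range 35000 nM to 100000 nM, a step of a 1.2-fold higher number from compound 1 to compound 4 (0.09 log units; within the scatter) expected.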

Compound 4, half-maximal inhibitory concentration: 40500 nM
The estimate for compound 4 lay 1.8-fold (0.25 log units) above the measured number; the measured number falls inside the stated range.
By their numbers in this assay, from the lowest: compounds 4, 1 and 2 (each within the scatter of the next). At a limit, above all of these: compound 3.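

In this assay, among these compounds, the position on the amide nitrogen is now tested directly, with a 1.5-fold lower number from compound 1 to compound 4 (0.16 log units; within the scatter) as its only step. For this pair, cyclohexyl and 4-methylphenyl stand level, so the aromatic ring at this place is not needed to keep a number in this range. Nothing measured here offers a reason for that level result.

As far as these compounds go, whether a benzyl group or a longer alkyl chain on the amide nitrogen would stay level remains open. So does whether a carboxylic acid on the enter group would.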